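A few compounds are considered here, and "the series" means these few. Any claim that something is new, unique, unknown or untested is made for them only; others in the source may bear on it.

Compound 3 `NC(=O)[C@@H](CCC(F)(F)F)N(C[C@H]1COCCO1)S(=O)(=O)c1ccc(Cl)cc1` is one of three close relatives built on a shared core, and in an in vitro ADME assay on microsomes from liver (Homo sapiens) for metabolic stability, read by HPLC (a higher number here means faster removal of the compound, a lower number slower removal), compound 3 gives 176 mL/min/kg. That is the higher of the two plain numbers: compound 1 `CC1(C)C[C@H](CN([C@H](CCC(F)(F)F)C(N)=O)S(=O)(=O)c2ccc(Cl)cc2)O1` gives 29 mL/min/kg, and the gap is a 6.1-fold higher number from compound 1 to compound 3 (0.78 log units; beyond the scatter). Compound 2 `NC(=O)[C@@H](CCC(F)(F)F)N(C[C@@H]1CCCCO1)S(=O)(=O)c1ccc(Cl)cc1` gives only > 300 mL/min/kg, which is a limit of the assay rather than a number (the limit of > 300 mL/min/kg in this assay, at which 1 of the 3 values shown sits). Compound 4 `NC(=O)[C@@H](CCC(F)(F)F)N(C[C@@H]1CCOC1)S(=O)(=O)c1ccc(Cl)cc1` is not yet measured; it differs from compound 3 in one place: oxolan-3-yl in place of 1,4-dioxan-2-yl on a saturated chain carbon bound to a sulfonamide nitrogen. Three measured steps swap the ring on that same carbon: an at least 10-fold higher number from compound 1 to compound 2 (1.01 log units; beyond the scatter), a 6.1-fold higher number from compound 1 to compound 3 (0.78 log units; beyond the scatter) and an at least 1.7-fold lower number from compound 2 to compound 3 (0.23 log units; that floor lies within the scatter). The oxan-2-yl ring of compound 2 and the 1,4-dioxan-2-yl ring of compound 3 both gave higher numbers than the 4,4-dimethyloxetan-2-yl ring of compound 1, while the swap between those two stayed within the scatter. A step of about a 1.1-fold higher number from compound 3 to compound 4 (0.06 log units; within the scatter) in this assay is therefore expected, none beyond the scatter, with some chance of reaching the limit. Compound 4 is estimated at 200 mL/min/kg, within 90 mL/min/kg to 400 mL/min/kg.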

Compound 4, clearance: 69.8 mL/min/kg
Compound 4: the middle estimate sits 2.9-fold (0.46 log units) above what was measured; the whole stated range lies above it.
By their numbers in this assay, from the lowest: compound 1; then compound 4; then compound 3. At a limit, above all of these: compound 2.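

In this assay, the swap to oxolan-3-yl gives a 2.5-fold lower number from compound 3 to compound 4 (0.40 log units; beyond the scatter), so a ring change at this place on a saturated chain carbon bound to a sulfonamide nitrogen can produce a step beyond the scatter even among rings without a dimethyl-substituted oxetane. The same ring gives an at least 4.2-fold lower number from compound 2 to compound 4 (0.63 log units; beyond the scatter) and a 2.4-fold higher number from compound 1 to compound 4 (0.38 log units; beyond the scatter), which places compound 4 apart from all three earlier compounds, at a level none of their rings had reached. The step from compound 2 is only a floor, as compound 2 stands at a limit and not at a number: the limit of > 300 mL/min/kg in this assay, at which 1 of the 4 values shown sits.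

Oxolan-3-yl differs from 1,4-dioxan-2-yl in both ring size and hetero atom count, so the compounds shown cannot tell which of these goes with the step. As far as these compounds go, how an amine or a carboxylic acid on the ring at this place would behave also stays open.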